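The source may report more compounds than this note shows. Statements on the series, on what has been measured and on what is new or still open speak of the compounds shown alone.

Compound 1 `COc1ccc(-c2nn(-c3ccccc3)cc2C2CC(c3ccc(F)cc3)=NN2C(C)=O)cc1` and compound 3 `COc1ccc(-c2nn(-c3ccccc3)cc2C2CC(c3ccc(F)cc3)=NN2c2ccccc2)cc1` share most of their structure; the two cores differ by phenyl in place of acetyl on an amine nitrogen in a ring. In a functional assay on the whole organism (Tail) with Rattus norvegicus as the target, in the tail flick test, with a stated time of 60 min, at a dose of 25 mg/kg by the oral route (on this read-out higher numbers stand for more inhibition at the one dose given (going by the name of the read-out) and lower numbers for less inhibition), compound 1 gives 66%, and compound 3 gives 66%, which means no change at the digits printed from compound 1 to compound 3 (within the scatter). Compound 2 `CC(=O)N1N=C(c2ccc(F)cc2)CC1c1cn(-c2ccccc2)nc1-c1cccc([N+](=O)[O-])c1` is compound 1 after a single exchange, (3-nitrophenyl in place of 4-methoxyphenyl on an aromatic carbon); in this assay compound 2 gives 109%, so that a number 43 percentage points higher from compound 1 to compound 2 (beyond the scatter). Compound 4 `O=[N+]([O-])c1cccc(-c2nn(-c3ccccc3)cc2C2CC(c3ccc(F)cc3)=NN2c2ccccc2)c1` is the not yet measured partner of compound 3: it carries the same exchange, (3-nitrophenyl in place of 4-methoxyphenyl on an aromatic carbon), with the place described word for word as before, but applied to the core of compound 3 rather than that of compound 1. Among the compounds shown this exchange has been measured only once. Going by the values given here, for compound 4 a step of similar size is expected, a number 39 percentage points higher from compound 3 to compound 4 (beyond the scatter), because a number 43 percentage points higher from compound 1 to compound 2 (beyond the scatter) is the sole measured example and is large, and because compound 3 gives 66%, the same starting level as compound 1. Compound 4 is therefore estimated at 105% in this assay, with a likely range from 85% to 125%. A single example is a thin basis, so the range is kept wide.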

Compound 4, a percentage reported as inhibition, in the whole organism at one dose (the size of the read-out at that dose, not a potency): 108%
The estimate for compound 4 lay 3 percentage points below the measured number; low and high end bracket the measured number.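

In this assay, 3-nitrophenyl in place of 4-methoxyphenyl also brings a large rise on the core with phenyl on the ring nitrogen, a number 42 percentage points higher from compound 3 to compound 4 (beyond the scatter), and this closely matches the earlier result on the acetyl core: the same change on two cores in this assay, a number 43 percentage points higher (beyond the scatter) from compound 1 to compound 2 and a number 42 percentage points higher (beyond the scatter) from compound 3 to compound 4, 1 percentage points apart, within the scatter of two such steps. The other exchange, phenyl in place of acetyl, again makes no real difference when the 3-nitrophenyl group is present, a number 1 percentage points lower from compound 2 to compound 4 (within the scatter), so it too carries over: the same change on two cores in this assay, no change at the digits printed (within the scatter) from compound 1 to compound 3 and a number 1 percentage points lower (within the scatter) from compound 2 to compound 4, 1 percentage points apart, within the scatter of two such steps. Together, these four compounds show the two exchanges acting independently of each other, but they cover only two cores and one dose, so they give the size of an effect rather than a potency and do not show why either exchange acts as it does.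

The compounds shown leave open whether the rise depends on the nitro group itself, or whether another group on the phenyl ring, such as a nitrile or a carboxylic acid, would give the same result. As far as these compounds go, it is also open whether a different group on the ring nitrogen, such as an amine-bearing chain, would leave the read-out as unchanged as phenyl and acetyl do.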